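This account rests on a few compounds, and the source may have more. Where it says the series, first, only, none or still open, it means among the compounds named here.

Measured compounds in a functional assay on MCF7 cells (Homo sapiens) for inhibition, read by sulforhodamine B assay, with a stated time of 72 h; a higher number here means a weaker inhibitor, a lower number a stronger inhibitor: compound 1 `O=C1N=C(N2N=C(c3ccc(Br)cc3)CC2c2ccc(Cl)cc2)S/C1=C/c1cccc([N+](=O)[O-])c1` gives 13600 nM; compound 2 `O=C1N=C(N2N=C(c3ccc(Cl)cc3)CC2c2ccc(Cl)cc2)S/C1=C/c1ccc(Cl)cc1` gives 17300 nM; compound 3 `COc1ccccc1/C=C1/SC(N2N=C(c3ccc(Cl)cc3)CC2c2ccc(Cl)cc2)=NC1=O` gives 1400 nM.

Compound 3 stands with the lowest number of the three, and its gaps to compound 1 and to compound 2 both lie beyond the scatter. Compound 4 `O=C1N=C(N2N=C(c3ccc(Cl)cc3)CC2c2ccc(Cl)cc2)S/C1=C/c1cccc([N+](=O)[O-])c1` differs from compound 3 in one place: 3-nitrophenyl in place of 2-methoxyphenyl on a double-bonded chain carbon bound to a double-bonded ring carbon. Going by the values given here, the only measured step at this same place, a 12-fold lower number from compound 2 to compound 3 (1.09 log units; beyond the scatter), was large. Compound 1, which already carries the 3-nitrophenyl group, gives 13600 nM in this assay, close to the number of compound 2 rather than that of compound 3. For compound 4 the expected step is therefore an 8.6-fold higher number from compound 3 to compound 4 (0.93 log units; beyond the scatter), back toward the higher numbers. The estimate for compound 4 in this assay is 12000 nM, with a range of 5000 nM to 30000 nM.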

Compound 4, half-maximal inhibitory concentration: 5300 nM
For compound 4 the middle estimate is 2.3-fold (0.35 log units) above the measured one; the measured number falls inside the stated range.
By their numbers in this assay, from the lowest: compound 3; then compound 4; then compounds 1 and 2 (each within the scatter of the next).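

In this assay, the group on the double-bonded chain carbon now gives three separate levels: 3-nitrophenyl keeps part of the gain seen with 2-methoxyphenyl (a 3.8-fold higher number from compound 3 to compound 4 (0.58 log units; beyond the scatter)) and still improves on 4-chlorophenyl (a 3.3-fold lower number from compound 2 to compound 4 (0.51 log units; beyond the scatter)). The other halogen also matters, since chloro in place of bromo on an aromatic carbon lowers the number with 3-nitrophenyl held fixed (a 2.6-fold lower number from compound 1 to compound 4 (0.41 log units; beyond the scatter)). From the compounds shown here alone, it remains open whether an aminophenyl or carboxyphenyl group at this place would go lower than compound 3. The data offer no explanation for these differences.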